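Unmasking a Hydroxy Group on the Shared Core

This account rests on a few compounds, and the source may have more. Where it says the series, first, only, none or still open, it means among the compounds named here.

Compound 1, `COc1cc(Cl)cc(-c2nn(-c3cccc(NC(=O)Nc4ccc(Cl)c(C(F)(F)F)c4)c3)cc2-c2ccncc2)c1`, gives 59%
Compound 2, `COc1cc(Cl)cc(-c2nn(-c3cccc(NC(=O)c4cccc(C(F)(F)F)c4)c3)cc2-c2ccncc2)c1`, gives 98%
Compound 3, `COc1cc(Cl)cc(-c2nn(-c3cccc(NC(=O)Nc4ccc(Cl)c(Cl)c4)c3)cc2-c2ccncc2)c1`, gives 87%

These three compounds share one core and were compared in a functional assay on SF-295 cells (Homo sapiens) for inhibition, read by sulforhodamine B assay, with a stated time of 48 h, tested at 0.01 uM; a higher number here means a weaker effect of the compound at the concentration tested, a lower number a stronger effect. Compound 1 stands lowest of the three, with compound 3 nearest and compound 2 furthest: the change from a urea to an amide on the carbonyl carbon gave a number 39 percentage points higher from compound 1 to compound 2 (beyond the scatter), and the swap of chloro for trifluoromethyl on an aromatic carbon gave a number 28 percentage points higher from compound 1 to compound 3 (beyond the scatter). Both measured steps beyond compound 1 therefore touch the urea end of the molecule.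

Compound 4, `O=C(Nc1cccc(-n2cc(-c3ccncc3)c(-c3cc(O)cc(Cl)c3)n2)c1)Nc1ccc(Cl)c(C(F)(F)F)c1`, is reached from compound 1 by a different route: hydrogen in place of methyl on an oxygen on an aromatic ring. Within the data shown here, no measured step in this set alters that oxygen, so the two steps from compound 1 to compound 2 and from compound 1 to compound 3 say nothing direct about it. With nothing to tie this change to a known shift in this assay, the account expects the step from compound 1 to compound 4 to stay within the scatter, estimated as a number 3 percentage points higher from compound 1 to compound 4 (within the scatter). On that basis compound 4 is expected to give roughly 62%, with a range from 40% to 85%.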

Compound 4, a percentage reported as activity, at one concentration (the size of the read-out at that concentration, not a potency): 58%
The estimate for compound 4 lay 4 percentage points above the measured number, and the stated range covers the measured number.
By their numbers in this assay, from the lowest: compounds 4 and 1 (each within the scatter of the next); then compound 3; then compound 2.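

Hydrogen in place of methyl on the oxygen of the 3-chloro-5-methoxyphenyl group gives a number 1 percentage points lower from compound 1 to compound 4 (within the scatter) in this assay, so compound 1 and compound 4 stand level at the concentration tested. Among these compounds, this is the first step in the set at this end of the molecule, and, unlike the two steps from compound 1 at the urea end (a number 39 percentage points higher from compound 1 to compound 2 (beyond the scatter); a number 28 percentage points higher from compound 1 to compound 3 (beyond the scatter)), it stays within the scatter, so methoxy to hydroxy here leaves the read-out indistinguishable. The information at hand offers no measurement that bears on why this is so.

The compounds shown leave open whether the same holds for other groups at this place, such as an ethoxy group, a longer alkoxy chain or an amine in place of the hydroxy. They also leave open whether hydroxy and methoxy would stay level with the amide of compound 2 or the 3,4-dichlorophenyl urea of compound 3, since this one pair carries only the 4-chloro-3-(trifluoromethyl)phenyl urea.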